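The compounds below may be only part of what the source reports. "The series", "measured", "known", "first", "only" and "open" are said of these compounds alone.

Compound 1 `CCCCNC(=O)N1CCC(Oc2cc3nccc(Oc4ccc(NC(=O)NN5C(=O)CSC5c5ccc(F)cc5)cc4)c3cc2OC)CC1` gives 1700 nM in a functional assay on HT-29 cells (Homo sapiens) for inhibition, read by MTT assay; on this read-out higher numbers stand for weaker inhibition and lower numbers for stronger inhibition.
Compound 2 `COc1cc2c(Oc3ccc(NC(=O)NN4C(=O)CSC4c4ccc(F)cc4)cc3)ccnc2cc1OC1CCN(C(=O)NC2CCCCC2)CC1` gives 3420 nM.
Compound 3 `COc1cc2c(Oc3ccc(NC(=O)NN4C(=O)CSC4c4ccccc4)cc3)ccnc2cc1OC1CCN(C(=O)NC(C)C)CC1` gives 1260 nM.

Compound 3 stands at the lowest of the three numbers; compound 1 lies within the scatter of it, compound 2 beyond it. Compound 4 `COc1cc2c(Oc3ccc(NC(=O)NN4C(=O)CSC4c4ccc(F)cc4F)cc3)ccnc2cc1OC1CCN(C(=O)NC(C)C)CC1` differs from compound 3 by 2,4-difluorophenyl in place of phenyl on a saturated ring carbon. Among the compounds with values here, no measured step touches this part of the molecule: the only step, a 2.0-fold higher number from compound 1 to compound 2 (0.30 log units; within the scatter), concerns the group on the amide-type nitrogen and was within the scatter. Compound 1 and compound 3 differ in more than one place, and their values lie within the scatter of each other. There is thus no ground to expect more than a small step, and compound 4 is estimated at 1400 nM, between 600 nM and 3500 nM, a step of a 1.1-fold higher number from compound 3 to compound 4 (0.05 log units; within the scatter) expected to stay within the scatter.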

Compound 4, half-maximal inhibitory concentration: 950 nM
Compound 4: middle estimate off by 1.5-fold (0.17 log units), on the high side; measured number inside the range.
By their numbers in this assay, from the lowest: compounds 4, 3, 1 and 2 (each within the scatter of the next, the first and the last beyond it).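

In this assay, 2,4-difluorophenyl in place of phenyl on the saturated ring carbon gives a 1.3-fold lower number from compound 3 to compound 4 (0.12 log units; within the scatter) and is the first step shown at this position. This position therefore carries the two added fluorine atoms with no change beyond the scatter. Nothing measured here speaks to what lies behind this step.

From the compounds shown here alone, whether an amine or a carboxylic acid on this phenyl ring would shift the number beyond the scatter remains open. So does whether 2,4-difluorophenyl gives a similar step alongside the butyl or cyclohexyl group on the amide-type nitrogen.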